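The compounds below may be only part of what the source reports. "The series", "measured", "known", "first", "only" and "open" are said of these compounds alone.

Measured compounds:
compound 1 `CCCc1nc(-c2ccccc2)c(CNCCN2CCN(c3ccccc3Cl)CC2)o1`: 4370 nM
compound 2 `CCCc1nc(-c2ccccc2)c(CNCCCN2CCN(c3ccc(F)cc3)CC2)o1`: 3210 nM
compound 3 `CCCc1nc(-c2ccccc2)c(CNCCN2CCN(c3cccc(F)c3)CC2)o1`: 3350 nM

These three compounds share one core and were tested in an assay on HEK293 cells for inhibition of Voltage-dependent T-type calcium channel subunit alpha-1G (Homo sapiens), read by patch clamp; on this read-out higher numbers stand for weaker inhibition and lower numbers for stronger inhibition. Compound 2 gives 3210 nM, the smallest of the three numbers, but the gaps to compound 3 and to compound 1 are both within the scatter, so the three are not separated by this assay. The single-place step measured so far, a 1.3-fold lower number from compound 1 to compound 3 (0.12 log units; within the scatter), also stays within the scatter.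

Compound 4 `CCCc1nc(-c2ccccc2)c(CNCCCN2CCN(c3ccc(C)cc3)CC2)o1` is not yet measured. It differs from compound 2 by methyl in place of fluoro on an aromatic carbon. Among the measured compounds shown here, no measured step exchanges fluoro for methyl on this ring, so the only guide is indirect: the one change of the aromatic group on the ring nitrogen, a 1.3-fold lower number from compound 1 to compound 3 (0.12 log units; within the scatter), moved the number hardly at all. On that basis no step beyond the scatter is expected in this assay. Compound 4 is therefore estimated at 3200 nM, with a range from 1500 nM to 7000 nM, which would mean an expected step of a 1.0-fold lower number from compound 2 to compound 4 (0.00 log units; within the scatter).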

Compound 4, half-maximal inhibitory concentration: 130000 nM
Estimate against measurement, compound 4: 41-fold (1.61 log units) below; the measured number lies above the stated range.
By their numbers in this assay, from the lowest: compounds 2, 3 and 1 (each within the scatter of the next); then compound 4.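

In this assay the exchange of 4-fluorophenyl for 4-methylphenyl gives a 40-fold higher number from compound 2 to compound 4 (1.61 log units; beyond the scatter) and so lies far beyond the scatter, whereas the earlier change of the aromatic group, a 1.3-fold lower number from compound 1 to compound 3 (0.12 log units; within the scatter) stayed within it. This position, on an aromatic carbon para to a large group, therefore does not accept every small exchange: one heavy atom replacing one heavy atom, with no hydrogen-bond donor, acceptor or net charge on either side, is enough to set compound 4 apart from the other three. Nothing measured here explains why this single exchange has so large an effect.

On these data alone, it remains open whether methyl is unusual at this position or whether ethyl, methoxy or an amine there would also give much weaker inhibition. A plain hydrogen at this position would show whether fluoro helps or methyl harms.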